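An Allyl Group on the Phenol Oxygen of Compound 1

This account rests on a few compounds, and the source may have more. Where it says the series, first, only, none or still open, it means among the compounds named here.

Measured so far:
compound 1, `O=C(c1cccnc1)c1ccccc1O`: 31000 nM
compound 2, `O=C(c1cccnc1)c1ccc(Br)cc1O`: 85000 nM
compound 3, `O=C(c1cccnc1)c1cc(F)ccc1O`: 12000 nM

All three numbers come from a functional assay on Hep cells (Homo sapiens) for cytotoxicity, read by sulforhodamine B assay, with a stated time of 48 h; on this read-out higher numbers stand for weaker inhibition and lower numbers for stronger inhibition. Compound 1 stands second highest of the three: compound 3 sits closer to it, a 2.6-fold lower number from compound 1 to compound 3 (0.41 log units; beyond the scatter), and compound 2 lies further off, a 2.7-fold higher number from compound 1 to compound 2 (0.44 log units; beyond the scatter).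

The next compound, compound 4, `C=CCOc1ccccc1C(=O)c1cccnc1`, differs from compound 1 by allyl in place of hydrogen on an oxygen on an aromatic ring. Going by the values given here, the two measured steps both concern a halogen on an aromatic carbon, and each was modest; neither touches the oxygen, so no measured step bears directly on this change. What is known only shows that single substitutions on this core move the number by modest amounts in either direction.

The expectation for compound 4 is therefore a step from compound 1 of about a 1.1-fold higher number from compound 1 to compound 4 (0.05 log units; within the scatter), that is, no change beyond the scatter, with a wide range. The estimated value for compound 4 is 35000 nM, between 12000 nM and 110000 nM.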

Compound 4, half-maximal inhibitory concentration: > 100000 nM
Compound 4: only a limit was reported (the forecaster's own chance of this, stated with the estimate: 15%); middle value at least 2.8-fold (0.45 log units) away from the limit.
By their numbers in this assay, from the lowest: compound 3; then compound 1; then compound 2. At a limit, above all of these: compound 4.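

In this assay compound 4 gives > 100000 nM, which is a limit of the assay and not a number. Allyl in place of hydrogen on an oxygen on an aromatic ring gives an at least 3.2-fold higher number from compound 1 to compound 4 (0.50 log units; beyond the scatter), so this oxygen, untouched by the halogen changes on the aromatic carbons, is also a place where one substitution moves the number, here towards weaker inhibition. The direction and a minimum size can be read, but the full size of the step cannot: the limit of > 100000 nM in this assay, at which 1 of the 4 values shown sits.

The compounds shown leave open whether the shift comes from losing the hydrogen on this oxygen or from the allyl group itself. A methyl group or a longer chain ending in an amine on the same oxygen could help to separate these two readings.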